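A few compounds are considered here, and "the series" means these few. Any claim that something is new, unique, unknown or untested is made for them only; others in the source may bear on it.

Working notes on the series, values in a functional assay on KB cells (Homo sapiens) for cytotoxicity; a higher number here means a weaker inhibitor, a lower number a stronger inhibitor:

- compound 1 `Cc1ccc(S(=O)(=O)Oc2ccc3c(c2)C(=O)C=CC3=O)cc1`: 16400 nM
- compound 2 `C=CCOc1ccc2c(c1)C(=O)C=CC2=O`: 10200 nM
- compound 3 `O=C1C=CC(=O)c2cc(OCc3ccccc3)ccc21`: 26200 nM

Compound 2 at 10200 nM and compound 1 at 16400 nM lie within the scatter of each other and share the low end of the three values. Compound 3 lies clearly higher, shown by a 2.6-fold higher number from compound 2 to compound 3 (0.41 log units; beyond the scatter).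

The next compound is compound 4 `CS(=O)(=O)Oc1ccc2c(c1)C(=O)C=CC2=O`, not yet measured. The change from compound 2 is methylsulfonyl in place of allyl on an oxygen on an aromatic ring.

Among the compounds with values here, only one measured step bears on this oxygen: a 2.6-fold higher number from compound 2 to compound 3 (0.41 log units; beyond the scatter). It is modest, and it swaps phenyl for vinyl further out on the chain, so it gives only a rough size for changes at this place and no direct guide to a sulfonyl group. Within the data shown here, compound 1, the only measured compound with a sulfonyl group on that oxygen, gives 16400 nM, which points to a small move at most. A small rise in this assay is therefore expected, probably within the scatter. The expected step is a 1.4-fold higher number from compound 2 to compound 4 (0.14 log units; within the scatter). For compound 4 the estimated value is 14000 nM, with an expected range of 5500 nM to 35000 nM.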

Compound 4, half-maximal inhibitory concentration: 11600 nM
Compound 4: middle estimate off by 1.2-fold (0.08 log units), on the high side, within the range that was stated.
By their numbers in this assay, from the lowest: compounds 2, 4, 1 and 3 (each within the scatter of the next, the first and the last beyond it).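

In this assay, within the data shown here, the first direct exchange of a carbon chain for a sulfonyl group on this oxygen, methylsulfonyl in place of allyl, gives a 1.1-fold higher number from compound 2 to compound 4 (0.06 log units; within the scatter) and does not separate the two compounds. Among these compounds, on the sulfonyl sulfur, methyl in place of 4-methylphenyl gives a 1.4-fold lower number from compound 1 to compound 4 (0.15 log units; within the scatter) despite the loss of the aromatic ring, so compound 1 and compound 4 are not separated either, and the only step at this place beyond the scatter remains a 2.6-fold higher number from compound 2 to compound 3 (0.41 log units; beyond the scatter) on the ether side. No measurement accompanying the series offers an explanation for these results.

On these data alone, whether a free hydroxyl on this oxygen, or an amine, a carboxylic acid or a longer chain carried on it, would give a step beyond the scatter remains open, as does whether a sulfonyl group with a benzyl or other larger substituent on the sulfur would behave like compound 1 or like compound 3. All the changes shown sit on this one oxygen, so the response to substitution elsewhere on the shared core is also unknown.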